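The source may hold more compounds than are shown below. What is called first, only, known or untested is meant among the compounds shown, and "the series" means these compounds.

Measured compounds:
compound 1, `Cc1ccc(CS/C(=C/c2ccc(C)s2)C(=O)c2ccc(Cl)cc2)cc1`, 50000 nM
compound 2, `Cc1ccc(/C=C(/Sc2ccc(F)cc2)C(=O)c2ccc(Cl)cc2)s1`, 25000 nM
compound 3, `O=C(/C(=C\c1ccc[nH]1)SCc1ccc(Cl)cc1)c1ccc(Cl)cc1`, 10000 nM

Of the compounds shown here, three of a shared core have been tested in a functional assay on DU-145 cells (Homo sapiens) for inhibition, read by trypan blue exclusion, with a stated time of 96 h; a lower number here means a stronger inhibitor of growth, a higher number a weaker inhibitor of growth. Going by the values given here, compound 1 gives 50000 nM and compound 2 gives 25000 nM; the one change between them, 4-fluorophenyl in place of 4-methylbenzyl on a sulfur, yields a 2.0-fold lower number from compound 1 to compound 2 (0.30 log units; within the scatter), which says little. Compound 3 stands lowest of the three, giving 10000 nM, a gap to compound 2 and to compound 1 that lies beyond the scatter in both cases.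

The next compound, compound 4 with the structure `Cc1ccc(/C=C(/SCc2ccc(Cl)cc2)C(=O)c2ccc(Cl)cc2)s1`, differs from compound 3 in one place: 5-methylthiophen-2-yl in place of 1H-pyrrol-2-yl on a double-bonded chain carbon bound to a double-bonded chain carbon. Among the compounds with values here, no measured pair shows this exchange, so no step bears on it directly. What can be said is that compound 1 and compound 2 both carry the 5-methylthiophen-2-yl group and both give higher numbers than compound 3, while compound 4 keeps the sulfur substituent of compound 3 and takes the ring of compound 1 and compound 2. On that footing the expected step from compound 3 is upward, toward the numbers of compound 1 and compound 2, an estimated 3.0-fold higher number from compound 3 to compound 4 (0.48 log units; beyond the scatter). Compound 4 is therefore expected to give about 30000 nM in this assay, within an estimated range from 10000 nM to 80000 nM.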

Compound 4, concentration for 50% growth inhibition: 50000 nM
Compound 4: middle estimate off by 1.7-fold (0.22 log units), on the low side; measured number inside the range.
By their numbers in this assay, from the lowest: compound 3; then compounds 2, 1 and 4 (each within the scatter of the next).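

In this assay, the exchange on a double-bonded chain carbon bound to a double-bonded chain carbon now has a direct reading, with 5-methylthiophen-2-yl in place of 1H-pyrrol-2-yl giving a 5.0-fold higher number from compound 3 to compound 4 (0.70 log units; beyond the scatter) when the 4-chlorobenzyl group on the sulfur is held fixed. With 5-methylthiophen-2-yl in this position, neither of the other exchanges can be told from the scatter: 4-chlorobenzyl in place of 4-fluorophenyl on a sulfur gives a 2.0-fold higher number from compound 2 to compound 4 (0.30 log units; within the scatter) and chloro in place of methyl on an aromatic carbon gives no change at the digits printed from compound 1 to compound 4 (within the scatter), so among these compounds only the exchange of 1H-pyrrol-2-yl goes beyond the scatter. Nothing measured here accounts for the step at this position.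

The exchange swaps the ring's hetero atom and adds a methyl at once, so a single pair cannot separate the two, and a plain thiophen-2-yl or a 1-methylpyrrol-2-yl group would be needed to do so. Going by these compounds, whether 1H-pyrrol-2-yl gives a similar step with 4-fluorophenyl or 4-methylbenzyl on the sulfur also remains open, as does the outcome with a furan-2-yl ring in this position.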